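Pyrimidinyl for pyridinyl on the vinyl sulfone of compound 1

The compounds below may be only part of what the source reports. "The series", "measured", "known", "first", "only" and "open" are said of these compounds alone.

Compound 1, `COc1ccc(S(=O)(=O)/C=C/c2ccccn2)cc1`, is the reference point of this small set. In an ADME assay on BV-2 cells (Mus musculus) for cytotoxicity, with a stated time of 24 h, tested at 10 uM (a higher number here means a weaker effect of the compound at the concentration tested, a lower number a stronger effect), compound 1 gives 100%. Of the three measured compounds none lies beyond the scatter from compound 1: the nearest is compound 2, `COc1ccc(S(=O)(=O)/C=C/c2cccc(Cl)n2)cc1`, which gives 97%, and the furthest is compound 3, `COc1ccc(S(=O)(=O)/C=C/c2ncccc2F)cc1`, which gives 94.2%. The two steps that start from compound 1 are a number 3 percentage points lower from compound 1 to compound 2 (within the scatter) and a number 5.8 percentage points lower from compound 1 to compound 3 (within the scatter); both are additions of a single halogen on an aromatic carbon and both stay within the scatter.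

Compound 4, `COc1ccc(S(=O)(=O)/C=C/c2cncnc2)cc1`, has not yet been measured. It differs from compound 1 by pyrimidin-5-yl in place of pyridin-2-yl on a double-bonded chain carbon bound to a double-bonded chain carbon. Among the compounds with values here, no measured step exchanges the aromatic ring itself, so the two halogen steps bear on this change only loosely; what they do show is that small alterations to that ring left the read-out essentially unchanged, and nothing in the set suggests that a heteroaryl swap of this kind would move it beyond the scatter either.

Compound 4 is therefore expected to show a number 4 percentage points lower from compound 1 to compound 4 (within the scatter), that is, no step beyond the scatter. The estimated value for compound 4 is 96%, with a range from 84% to 104%.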

Compound 4, a percentage reported as activity, at one concentration (the size of the read-out at that concentration, not a potency): 100%
The estimate for compound 4 lay 4 percentage points below the measured number; low and high end bracket the measured number.
By their numbers in this assay, from the lowest: compounds 3, 2, 1 and 4 (each within the scatter of the next).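

Where the earlier steps only added a halogen to the pyridin-2-yl ring, this step replaces the ring itself with pyrimidin-5-yl on the same double-bonded chain carbon, and it gives no change at the digits printed from compound 1 to compound 4 (within the scatter) in this assay. The tolerance seen so far at this place therefore extends beyond halogen additions to an exchange of the whole aromatic group, and all four compounds now lie within the scatter of one another, with none that goes against this. Why the read-out stays level cannot be said, as no supporting measurement bears on this result.

The compounds shown leave open whether anything at this place would move the read-out beyond the scatter, since every group here is a six-membered aromatic ring, and a carboxylic acid, a primary amine or a longer alkyl chain would test the limits of this tolerance far more severely. They also leave open whether the methoxy group on the other side of the sulfone can be replaced, for example by an amine, with the same outcome, and how any of these compounds would behave at other concentrations.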